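Moving the trifluoromethyl group on the sulfonyl aryl ring

The source may report more compounds than this note shows. Statements on the series, on what has been measured and on what is new or still open speak of the compounds shown alone.

In an ADME assay on microsomes from liver (Homo sapiens) for metabolic stability, read by LC-MS, with a stated time of 30 min, tested at 1 uM (a lower number here means that less of the compound is left, a higher number that more of the compound is left), compound 3 `O=C(NCc1ccc(S(=O)(=O)c2ccccc2C(F)(F)F)cc1)c1cc2cnccc2[nH]1` gives 52%, within the scatter of compound 1 `Cc1ccccc1S(=O)(=O)c1ccc(CNC(=O)c2cc3cnccc3[nH]2)cc1` at 48%. Compound 2 `O=C(NCc1ccc(S(=O)(=O)c2cccc(F)c2)cc1)c1cc2cnccc2[nH]1`, at 79%, stands clear of both.

The next compound is compound 4 `O=C(NCc1ccc(S(=O)(=O)c2cccc(C(F)(F)F)c2)cc1)c1cc2cnccc2[nH]1`, with 3-(trifluoromethyl)phenyl in place of 2-(trifluoromethyl)phenyl on a sulfonyl sulfur. For the measured compounds named here, no measured pair isolates this kind of change, so the evidence is indirect.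

Trifluoromethyl in place of methyl gave a number 4 percentage points higher from compound 1 to compound 3 (within the scatter), a step within the scatter. The two steps involving the 3-fluorophenyl compound are beyond it: a number 31 percentage points higher from compound 1 to compound 2 (beyond the scatter), which is large, and a number 27 percentage points lower from compound 2 to compound 3 (beyond the scatter), which is modest. Among these three compounds, the 2-methylphenyl and 2-(trifluoromethyl)phenyl members therefore sit together, and the 3-fluorophenyl member stands apart. None of the three goes against this, but the set is very small.

Compound 4 shares the 3-substituted naming with compound 2 at 79%, yet it carries trifluoromethyl rather than fluoro, so only part of that gap is expected to be recovered. The expected change in this assay is upward, an estimated a number 15 percentage points higher from compound 3 to compound 4 (beyond the scatter). For compound 4 the estimated value is 67%, with an expected range of 52% to 82%.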

Compound 4, percent of the compound remaining: 81%
For compound 4 the middle estimate is 14 percentage points below the measured one, within the range that was stated.
By their numbers in this assay, from the lowest: compounds 1 and 3 (each within the scatter of the next); then compounds 2 and 4 (each within the scatter of the next).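

For the compounds shown here, the 3>4 pair is the first to isolate placement on the ring: the two compounds have the same atoms, joined differently, and in this assay 3-(trifluoromethyl)phenyl in place of 2-(trifluoromethyl)phenyl on a sulfonyl sulfur gives a number 29 percentage points higher from compound 3 to compound 4 (beyond the scatter) in a single step. Trifluoromethyl in place of fluoro gives a number 2 percentage points higher from compound 2 to compound 4 (within the scatter) and so leaves the 3-fluorophenyl and 3-(trifluoromethyl)phenyl members together, which separates this step from the one between the two trifluoromethyl isomers. With a number 33 percentage points higher from compound 1 to compound 4 (beyond the scatter) as a further step, the four compounds fall into a 2-methylphenyl and 2-(trifluoromethyl)phenyl pair and a 3-fluorophenyl and 3-(trifluoromethyl)phenyl pair, and none of the four goes against this split. Nothing at hand bears on why the placement of the group tracks with the percent remaining.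

Going by these compounds, whether 3-methylphenyl on the sulfonyl sulfur would join the 3-fluorophenyl and 3-(trifluoromethyl)phenyl pair remains open, and it would test the split with the methyl group of compound 1. Also open, on these data alone, is whether a nitrile, an amine or a carboxylic acid on the same aromatic ring would follow the split, since only methyl, fluoro and trifluoromethyl appear here.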